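The source may hold more compounds than are shown below. What is called first, only, known or untested is meant among the compounds shown, and "the series" means these compounds.

Among the compounds with values here, compound 2 `CCN(CC)CCCNc1nc(-c2ccc(NC(=O)Nc3ccc(F)cc3)cc2)nc2c(Cl)c(Cl)sc12` stands at the lower of the two numbers so far: in a functional assay on HT-29 cells (Homo sapiens) for cytotoxicity, read by MTT assay, with a stated time of 72 h (a lower number here means a stronger inhibitor, a higher number a weaker inhibitor), compound 2 gives 350 nM. Compound 1 `CN(C)CCCNc1nc(-c2ccc(NC(=O)Nc3ccc(F)cc3)cc2)nc2c(Cl)c(Cl)sc12` gives 430 nM in this assay, and the step of a 1.2-fold lower number from compound 1 to compound 2 (0.09 log units; within the scatter) is within the scatter, so the two are not distinguished. Compound 3 `CCN(CC)CCCNc1nc(-c2ccc(NC(=O)Nc3ccc(Cl)cc3Cl)cc2)nc2c(Cl)c(Cl)sc12` differs from compound 2 in one place: 2,4-dichlorophenyl in place of 4-fluorophenyl on an amide-type nitrogen. Within the data shown here, no measured step bears on this end of the molecule; the only measured step, a 1.2-fold lower number from compound 1 to compound 2 (0.09 log units; within the scatter), concerns the amine on the chain and says nothing about the aryl group on the urea. The expectation for compound 3 therefore rests on compound 2 alone, at 350 nM, with a wide range. The expected step is no change at the digits printed from compound 2 to compound 3 (within the scatter), none beyond the scatter. Compound 3 is estimated at 350 nM in this assay, expected to fall between 90 nM and 1400 nM.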

Compound 3, half-maximal inhibitory concentration: 1230 nM
Beside the measured number, compound 3's estimate is 3.5-fold (0.55 log units) below it; low and high end bracket the measured number.
By their numbers in this assay, from the lowest: compounds 2 and 1 (each within the scatter of the next); then compound 3.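

In this assay the aryl group on the urea's amide-type nitrogen proves to count, with a step of a 3.5-fold higher number from compound 2 to compound 3 (0.55 log units; beyond the scatter) for 2,4-dichlorophenyl in place of 4-fluorophenyl. Within the data shown here, the earlier pair changed only the amine on the chain and stayed within the scatter, so this is the first change to move the number beyond it, and it moves it towards weaker inhibition. Nothing measured here bears on why the number rises.

The change replaces fluorine with chlorine and adds a second chlorine in one step, so the compounds shown leave open which part goes with the rise, a question that 4-chlorophenyl or 2-chlorophenyl on the same nitrogen would address. Also open, on these data alone, is whether 2,4-dichlorophenyl would give a similar step with the dimethylamino chain of compound 1.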